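The source may report more compounds than this note shows. Statements on the series, on what has been measured and on what is new or still open speak of the compounds shown alone.

In a functional assay on MOLT-4 cells (Homo sapiens) for antiproliferative activity (on this read-out higher numbers stand for weaker inhibition and lower numbers for stronger inhibition), the three measured compounds give these values:

Compound 1, `COc1cc(C(=O)c2sc(-c3ccc(F)cc3)cc2N)cc(OC)c1OC`: 12 nM
Compound 2, `CCOc1ccc(-c2cc(N)c(C(=O)c3cc(OC)c(OC)c(OC)c3)s2)cc1`: 240 nM
Compound 3, `COc1cc(C(=O)c2sc(-c3ccsc3)cc2N)cc(OC)c1OC`: 8.8 nM

On these numbers compound 1 stands second highest of the three. Its nearest neighbour is compound 3, reached by a 1.4-fold lower number from compound 1 to compound 3 (0.13 log units; within the scatter), a change that swaps the whole 4-fluorophenyl ring for thiophen-3-yl and still leaves the result where it was. The furthest is compound 2, reached by a 20-fold higher number from compound 1 to compound 2 (1.30 log units; beyond the scatter), where a larger ethoxy group takes the place of the small fluoro on the same aromatic carbon and the inhibition becomes much weaker.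

Compound 4, `COc1cc(C(=O)c2sc(-c3ccccc3)cc2N)cc(OC)c1OC`, differs from compound 1 by hydrogen in place of fluoro on an aromatic carbon.

Among the compounds with values here, two measured steps bear on this. The step from compound 1 to compound 2 shows that growing the group at this carbon costs a great deal, while the step from compound 1 to compound 3 shows that a change of similar size at this end of the molecule can pass without effect. Here a single small fluoro leaves and only a hydrogen enters, so no large step in this assay is expected; a result within the scatter, perhaps leaning slightly weaker, is the estimate.

Compound 4 is therefore expected to give 16 nM, with a likely range from 6 nM to 45 nM. This estimate means a step of a 1.3-fold higher number from compound 1 to compound 4 (0.12 log units; within the scatter), expected to stay within the scatter.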

Compound 4, half-maximal inhibitory concentration: 5.3 nM
Compound 4: the middle estimate sits 3.0-fold (0.48 log units) above what was measured, and the stated range ends above it.
By their numbers in this assay, from the lowest: compounds 4, 3 and 1 (each within the scatter of the next, the first and the last beyond it); then compound 2.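

In this assay, taking the fluoro away altogether brings no loss and even a modest gain, with a 2.3-fold lower number from compound 1 to compound 4 (0.35 log units; beyond the scatter) as the step, so the fluoro is not needed at this carbon and the bare phenyl ring serves at least as well. With hydrogen now measured, the numbers at this carbon rise in order from hydrogen through fluoro to ethoxy, and the full span is a 45-fold lower number from compound 2 to compound 4 (1.66 log units; beyond the scatter) as the step, while the ring itself can still be exchanged, since a 1.7-fold lower number from compound 3 to compound 4 (0.22 log units; within the scatter) as a step stays within the scatter. Nothing measured here explains why hydrogen gives a lower number than fluoro.

The compounds shown leave open how the number moves for groups of intermediate size at this carbon, such as a chloro, methyl or methoxy group, and so where the steep loss seen with ethoxy sets in. They also leave open whether an amine or a carboxylic acid on this carbon would follow the same order, and whether a group added to the thiophen-3-yl ring would behave as it does on the phenyl ring.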